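An amino group in place of hydroxy on the shared core

The source may report more compounds than this note shows. Statements on the series, on what has been measured and on what is new or still open speak of the compounds shown alone.

Measured so far in a functional assay on MT4 cells (Homo sapiens) (a higher number here means that more compound is tolerated, a lower number that less compound is tolerated), are these compounds
- compound 1 `Cc1cn([C@@H]2O[C@H](CO[Si](C)(C)C(C)(C)C)[C@@]3(OS(=O)(=O)C=C3NCC(=O)C(=O)N3CCC3)[C@H]2O[Si](C)(C)C(C)(C)C)c(=O)n(C)c1=O` gives 17400 nM as its value
- compound 2 `Cc1cn([C@@H]2O[C@H](CO[Si](C)(C)C(C)(C)C)[C@@]3(OS(=O)(=O)C=C3NCC(=O)C(=O)O)[C@H]2O[Si](C)(C)C(C)(C)C)c(=O)n(C)c1=O` gives 31100 nM as its value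

Compound 2 at 31100 nM stands level with compound 1 within the scatter. Going by the values given here, the only measured step is a 1.8-fold higher number from compound 1 to compound 2 (0.25 log units; within the scatter) with hydroxy in place of azetidin-1-yl on a carbonyl carbon.

Compound 3 `Cc1cn([C@@H]2O[C@H](CO[Si](C)(C)C(C)(C)C)[C@@]3(OS(=O)(=O)C=C3NCC(=O)C(N)=O)[C@H]2O[Si](C)(C)C(C)(C)C)c(=O)n(C)c1=O` is still unmeasured and differs from compound 2 by amino in place of hydroxy on a carbonyl carbon in one place, with amino in place of hydroxy on a carbonyl carbon, so carboxy becomes carbamoyl. Among the compounds with values here, since a 1.8-fold higher number from compound 1 to compound 2 (0.25 log units; within the scatter) is the one measured change on a carbonyl carbon and stayed within the scatter, no step beyond the scatter is expected in this assay and no firm direction can be given. The estimated step is a 1.3-fold lower number from compound 2 to compound 3 (0.11 log units; within the scatter) and so remains small. Compound 3 is estimated at 24000 nM with 12000 nM to 48000 nM as its expected range.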

Compound 3, half-maximal cytotoxic concentration: 9590 nM
Compound 3: the middle estimate sits 2.5-fold (0.40 log units) above what was measured; the measured number lies below the stated range.
By their numbers in this assay, from the lowest: compounds 3, 1 and 2 (each within the scatter of the next, the first and the last beyond it).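

In this assay, going by these compounds alone, amino in place of hydroxy on the carbonyl carbon, which turns carboxy into carbamoyl, gives a 3.2-fold lower number from compound 2 to compound 3 (0.51 log units; beyond the scatter), the first step at this position that goes beyond the scatter. Amino in place of azetidin-1-yl at the same place gives a 1.8-fold lower number from compound 1 to compound 3 (0.26 log units; within the scatter), so compound 3 and compound 1 cannot be told apart, and only the gap from compound 2 to compound 3 is a real difference among the three. Nothing available explains why the hydroxy-to-amino change has this effect.

The compounds shown leave open how a methylamino group, a dimethylamino group or a methoxy group on this carbonyl carbon would compare with these three. They also leave open whether a longer chain in place of the carbamoylcarbonyl group would keep the numbers within this range.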